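The source may hold more compounds than are shown below. What is called first, only, known or untested is meant among the compounds shown, and "the series" means these compounds.

Compound 1 `ClCc1ccccc1Cn1cnc2c(Cl)nc(Cl)nc21` gives 310 nM.
Compound 2 `ClCc1cccc(Cn2cnc3ncnc(Cl)c32)c1` gives 1940 nM.
Compound 3 `ClCc1ccccc1Cn1cnc2ncnc(Cl)c21` gives 1900 nM.

All three values come from a functional assay on U-251 cells (Homo sapiens) for cytotoxicity, read by sulforhodamine B assay, with a stated time of 48 h; on this read-out higher numbers stand for weaker inhibition of growth and lower numbers for stronger inhibition of growth. Among the three, compound 1 stands lowest, that is, it inhibits growth most strongly: compound 3 sits at the nearest value, with a higher number, a gap that lies beyond the usual scatter, while compound 2 sits furthest, also with a higher number, likewise beyond the scatter. Compound 2 and compound 3 lie close to each other.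

Compound 4 `Nc1nc(Cl)c2ncn(Cc3ccccc3CCl)c2n1` has not been measured in this assay. It differs from compound 1 in one place: amino in place of chloro on an aromatic carbon. In words, an amino group replaces a chloro group on an aromatic carbon of the shared core. For the measured compounds named here, no measured pair shows this exact exchange, so the direction of the step cannot be read from the data. A change at this position has to be judged on general grounds: the exchange from chloro to amino can either help or hurt, and no neighbouring comparison is available to anchor it. The expectation is a modest loss of growth inhibition, with the step from compound 1 to compound 4 estimated at a 2.6-fold higher number from compound 1 to compound 4 (0.41 log units; beyond the scatter), though a step in either direction within this range would not be surprising. Compound 4 is therefore expected to give about 800 nM, with a likely range from 250 nM to 2500 nM.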

Compound 4, concentration for 50% growth inhibition: 3470 nM
The estimate for compound 4 lay 4.3-fold (0.64 log units) below the measured number; the measured number lies above the stated range.
By their numbers in this assay, from the lowest: compound 1; then compounds 3, 2 and 4 (each within the scatter of the next).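

In this assay, replacing the chloro group with an amino group on this aromatic carbon, between two ring nitrogen atoms, gives an 11-fold higher number from compound 1 to compound 4 (1.05 log units; beyond the scatter), a large loss of growth inhibition. For the compounds shown here, this is the first direct reading of the exchange at this position, and it shows that growth inhibition is far from indifferent to what sits there: swapping a single chlorine atom for a single nitrogen atom, while the rest of the molecule stays the same, is enough to produce a step of this size. Nothing available accounts for the size of this loss, so the result records what happens without saying why.

Going by these compounds alone, the single exchange leaves open whether the loss is specific to the amino group or would follow from removing the chloro group in favour of other small groups. A bromo, methoxy, methyl or methylamino group on the same carbon would help to separate these possibilities and show whether any replacement can match the growth inhibition of compound 1.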